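Two limits and a trifluoromethyl variant

The source may hold more compounds than are shown below. What is called first, only, known or untested is meant among the compounds shown, and "the series" means these compounds.

compound 1, `O=S(=O)(/C=C/c1ccccc1)Cc1ccc(Nc2ncnc3ccccc23)cc1`: > 100000 nM
compound 2, `O=S(=O)(/C=C/c1ccc(F)cc1F)Cc1ccc(Nc2ncnc3ccccc23)cc1`: > 100000 nM

In a functional assay on U-251 cells (Homo sapiens) (a higher number here means a weaker inhibitor of growth, a lower number a stronger inhibitor of growth), compound 1 gives > 100000 nM, which is a limit of the assay and not a number. Compound 2 likewise gives > 100000 nM, again a limit. The step that the two limits leave unreadable from compound 1 to compound 2 cannot be read because both values rest at the limit of > 100000 nM in this assay, at which 2 of the 2 values shown sit. Compound 3, `O=S(=O)(/C=C/c1ccc(C(F)(F)F)cc1F)Cc1ccc(Nc2ncnc3ccccc23)cc1`, differs from compound 1 in that (2-fluoro-4-(trifluoromethyl)phenyl in place of phenyl on a double-bonded chain carbon bound to a double-bonded chain carbon). Within the data shown here, the only measured step that touches the same place is the one from compound 1 to compound 2, and its size is not readable, so the measurements give no direction and no size for the move to compound 3. Compound 3 is therefore expected to stay at the same limit, with an estimated 100000 nM and a range from 30000 nM to 300000 nM. The expected step is a number no higher from compound 1 to compound 3 (the limit leaves the size open), which is offered only as an estimate.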

Compound 3, concentration for 50% growth inhibition: 100000 nM
The estimate for compound 3 equals the measured number at the digits printed; low and high end bracket the measured number.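

In this assay compound 3 gives 100000 nM, the first value shown that is a number and not a limit. The 2-fluoro-4-(trifluoromethyl)phenyl group on a double-bonded chain carbon bound to a double-bonded chain carbon therefore gives a readable value, but that value stands at the same figure as the limit of the other two compounds. The step of a number no higher from compound 1 to compound 3 (the limit leaves the size open) and the step of a number no higher from compound 2 to compound 3 (the limit leaves the size open) cannot be read in size, because their starting values are limits: the limit of > 100000 nM in this assay, at which 2 of the 3 values shown sit.

The compounds shown leave open whether any group at this place brings growth inhibition clear of that figure. Going by these compounds, a phenyl carrying an amine or a carboxylic acid, for instance, remains untested within this set.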